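A few compounds are considered here, and "the series" means these few. Any claim that something is new, unique, unknown or untested is made for them only; others in the source may bear on it.

Measured compounds:
Compound 1 `CC(=N)NCC1CCCc2cc(S(=O)(=O)c3ccccc3)ccc21` gives 0.631 nM.
Compound 2 `NC[C@@H]1CCCc2cc(S(=O)(=O)c3cc(F)cc4[nH]cnc34)ccc21` gives 5.01 nM.
Compound 3 `O=S(=O)(c1cccc(F)c1)c1ccc2c(c1)CCC[C@H]2CN1CC(O)C1` gives 0.1 nM.

These three were compared in an assay on isolated protein for displacement of a labelled ligand from 5-hydroxytryptamine receptor 6 (Homo sapiens); on this read-out lower numbers stand for stronger inhibition and higher numbers for weaker inhibition. Compound 3 stands lowest of the three numbers; its nearest neighbour is compound 1, whose value lies beyond the scatter above it, and compound 2 lies further still. Going by the values given here, no pair among them differs in only one place, so their values alone carry the comparison.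

Compound 4 `CC(C)(O)C(=O)NC[C@@H]1CCCc2cc(S(=O)(=O)c3cccc(F)c3)ccc21` has not yet been measured. It differs from compound 3 in one place: ((1-hydroxy-1-methylethyl)carbonyl)amino in place of 3-hydroxyazetidin-1-yl on a saturated chain carbon bound to a saturated ring carbon. Among the compounds with values here, no measured step isolates a change of this kind, so the expectation rests on compound 3 alone. Because compound 3 gives 0.1 nM and sits lowest of the numbers shown, a rise in the number is expected rather than a fall. The expected step is a 30-fold higher number from compound 3 to compound 4 (1.48 log units; beyond the scatter), beyond the scatter. Compound 4 is estimated at 3 nM, with a range from 0.5 nM to 20 nM.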

Compound 4, inhibition constant: 2 nM
Beside the measured number, compound 4's estimate is 1.5-fold (0.18 log units) above it; low and high end bracket the measured number.
By their numbers in this assay, from the lowest: compound 3; then compound 1; then compound 4; then compound 2.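

Going by these compounds alone, this is the only step that isolates a change on the saturated chain carbon bound to a saturated ring carbon. In this assay, ((1-hydroxy-1-methylethyl)carbonyl)amino in place of 3-hydroxyazetidin-1-yl gives a 20-fold higher number from compound 3 to compound 4 (1.30 log units; beyond the scatter), so the read-out at this position is sensitive to which of these two groups it carries. Even so, compound 4 still gives 2 nM, showing that a group with no ring and a carbonyl can stand here with a value in the range of the other compounds, while nothing at hand explains the size of the step.

The change removes the ring and brings in the carbonyl together, and these two parts cannot be told apart here. A dimethylamino group or a plain acetylamino group at the same place would begin to separate them.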